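The compounds below may be only part of what the source reports. "The series", "measured", "known", "first", "only" and "open" are said of these compounds alone.

The three measured compounds share one core and were examined in a functional assay on the whole organism (strain Kunming) for inhibition, with Mus musculus as the target, in the writhing test, at a dose of 40 mg/kg by the oral route; a lower number here means less inhibition, a higher number more inhibition at the dose given (going by the name of the read-out). In that test compound 1 `CC(=O)Oc1ccc(-c2ccc(F)cc2F)cc1C(=O)O` gives 0%, compound 2 `O=C(Oc1ccc(-c2ccc(F)cc2F)cc1C(=O)O)c1ccccc1` gives 7.97%, and compound 3 `CCNC(=O)c1cc(-c2ccc(F)cc2F)ccc1OC(C)=O` gives 23.9%. Compound 2 therefore stands second highest of the three numbers: compound 1 lies nearest, a little lower but within the scatter, while compound 3 lies furthest, higher and beyond the scatter. The step of a number 8 percentage points higher from compound 1 to compound 2 (within the scatter), phenyl in place of methyl on a carbonyl carbon, did not move the read-out beyond the scatter.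

Compound 4 `O=C(Oc1ccc(-c2ccc(F)cc2F)cc1C(=O)Nc1ccccc1)c1ccccc1` is not yet measured. It differs from compound 2 in one place: anilino in place of hydroxy on a carbonyl carbon. Going by the values given here, the only measured step of the same kind is a number 23.9 percentage points higher from compound 1 to compound 3 (beyond the scatter), where ethylamino replaced hydroxy on the same carbonyl carbon and the read-out rose modestly. Since compound 4 carries anilino rather than ethylamino, the account treats that gain as a guide rather than a fixed size. It expects compound 4 to give 28% in this assay, with a range from 10% to 48%. The expected step is a number 20 percentage points higher from compound 2 to compound 4 (beyond the scatter).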

Compound 4, a percentage reported as inhibition, in the whole organism at one dose (the size of the read-out at that dose, not a potency): 5.57%
Beside the measured number, compound 4's estimate is 22.4 percentage points above it; measured number outside the range, below it.
By their numbers in this assay, from the lowest: compounds 1, 4 and 2 (each within the scatter of the next); then compound 3.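

In this assay, the change from carboxy to phenylcarbamoyl gives a number 2.4 percentage points lower from compound 2 to compound 4 (within the scatter), so anilino in place of hydroxy on this carbonyl carbon leaves the read-out within the scatter, whereas ethylamino in the same place gave a number 23.9 percentage points higher from compound 1 to compound 3 (beyond the scatter). Replacing the hydroxy with an amine-derived group therefore does not by itself bring a rise beyond the scatter in these compounds. The two steps differ both in the entering group and in the other acyl group, methyl in compound 3 and phenyl in compound 4, and nothing available here explains the contrast between them.

The compounds shown do not separate these two differences, as they leave open what ethylamino would do with phenyl on the other carbonyl carbon and what anilino would do with methyl there. They also leave open whether a benzylamino group, a longer chain such as butylamino, or a tertiary amide such as dimethylcarbamoyl on this carbonyl carbon would follow compound 3 or compound 4.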